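The compounds below may be only part of what the source reports. "The series", "measured", "known", "first", "only" and "open" are said of these compounds alone.

Compound 1 `Cc1cc(C)cc(S(=O)(=O)c2c(C(=O)NCc3cccc(N)c3)[nH]c3ccc(Cl)cc23)c1` reaches in an ADME assay on MT4 cells (Homo sapiens) for cytotoxicity, read by MTT assay (a lower number here means that less compound is tolerated, a higher number that more compound is tolerated), only a limit, > 53400 nM, and no number is known for it. Among the compounds with values here, compound 2 `Cc1cc(C)cc(S(=O)(=O)c2c(C(=O)NC(C)C(=O)NC(C)c3ccncc3)[nH]c3ccc(Cl)cc23)c1` gives 21900 nM in this assay, the only number in the set. Compound 1 contributes (the limit of > 53400 nM in this assay, at which 1 of the 2 values shown sits). Compound 3 `Cc1cc(C)cc(S(=O)(=O)c2c(C(=O)NC(C)C(=O)NCc3ccccc3F)[nH]c3ccc(Cl)cc23)c1` carries 2-fluorobenzyl in place of 1-(pyridin-4-yl)ethyl on an amide-type nitrogen. Within the data shown here, no measured step joins two compounds here, so the size of the change is open; the step of a 1.1-fold higher number from compound 2 to compound 3 (0.06 log units; within the scatter) is expected to stay within the scatter of this assay, in no set direction. For compound 3 the estimate in this assay is 25000 nM, with a range from 10000 nM to 60000 nM.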

Compound 3, half-maximal cytotoxic concentration: 23300 nM
Compound 3: middle estimate off by 1.1-fold (0.03 log units), on the high side; the measured number falls inside the stated range.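

In this assay, within the data shown here, 2-fluorobenzyl in place of 1-(pyridin-4-yl)ethyl on the amide-type nitrogen gives a 1.1-fold higher number from compound 2 to compound 3 (0.03 log units; within the scatter), the first step that can be read. At this position, an aromatic ring with a hetero atom can thus give way to one of carbon only, carrying fluorine, with the two values staying within the scatter. No measurement shown bears on the reason for this result. Still open, from the compounds shown here alone, is how this assay reads with an amine or a carboxylic acid on this ring, or with a longer chain on this nitrogen.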